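Changing the Aryl Ring on the Carbonyl of Compound 2

This account rests on a few compounds, and the source may have more. Where it says the series, first, only, none or still open, it means among the compounds named here.

Measured compounds:
compound 1, `CCCCCCCCCCCCOc1ccc(C(=O)/C=C/c2c(/C=C/c3ccc(OC)cc3)cc(OC)cc2OC)cc1`: 7.9 ug/mL
compound 2, `COc1ccc(/C=C/c2cc(OC)cc(OC)c2/C=C/C(=O)c2cccc(Cl)c2)cc1`: 5.6 ug/mL
compound 3, `CCOc1ccc(C(=O)/C=C/c2c(/C=C/c3ccc(OC)cc3)cc(OC)cc2OC)cc1`: 7.5 ug/mL

In a functional assay on A549 cells (Homo sapiens) for antiproliferative activity, read by MTT assay, with a stated time of 48 h (on this read-out higher numbers stand for weaker inhibition and lower numbers for stronger inhibition), compound 2 gives 5.6 ug/mL, the lowest of the three numbers, yet neither gap separates it from the others: the step of a 1.3-fold higher number from compound 2 to compound 3 (0.13 log units; within the scatter) and the further step a 1.1-fold lower number from compound 1 to compound 3 (0.02 log units; within the scatter) both stay within the scatter, so no order among the three can be claimed.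

Compound 4, `COc1ccc(/C=C/c2cc(OC)cc(OC)c2/C=C/C(=O)c2ccc(C)cc2C)cc1`, differs from compound 2 only at the aryl group on the carbonyl carbon: 2,4-dimethylphenyl in place of 3-chlorophenyl on a carbonyl carbon. Among the compounds with values here, the one measured step at this same place, a 1.3-fold higher number from compound 2 to compound 3 (0.13 log units; within the scatter), produced no change beyond the scatter, and the step at the far end of the molecule, a 1.1-fold lower number from compound 1 to compound 3 (0.02 log units; within the scatter), likewise left the number where it was. On that basis compound 4 is expected to show no shift beyond the scatter, that is a 1.2-fold higher number from compound 2 to compound 4 (0.06 log units; within the scatter). The estimate for compound 4 in this assay is 6.5 ug/mL, with a range of 3 ug/mL to 14 ug/mL.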

Compound 4, half-maximal inhibitory concentration: 0.3 ug/mL
Compound 4: middle estimate off by 22-fold (1.34 log units), on the high side; the measured number lies below the stated range.
By their numbers in this assay, from the lowest: compound 4; then compounds 2, 3 and 1 (each within the scatter of the next).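

The aryl group on the carbonyl carbon proves not to be a silent place: in this assay, 2,4-dimethylphenyl in place of 3-chlorophenyl gives a large step (a 19-fold lower number from compound 2 to compound 4 (1.27 log units; beyond the scatter)), and in place of 4-ethoxyphenyl another (a 25-fold lower number from compound 3 to compound 4 (1.40 log units; beyond the scatter)), whereas the earlier change at this place (a 1.3-fold higher number from compound 2 to compound 3 (0.13 log units; within the scatter)) stayed within the scatter. Both large steps end at the same entering group, while the two groups that leave stand within the scatter of each other. Nothing in the data shown accounts for this result.

The compounds shown leave open whether both methyl groups are needed, or whether a phenyl carrying a single methyl group would give the same step. As far as these compounds go, it also remains open whether a dimethoxyphenyl or dichlorophenyl on the carbonyl carbon would follow compound 4 or stay with compound 2.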